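Anilino swap on the shared core: compound 3 to compound 4

The source may report more compounds than this note shows. Statements on the series, on what has been measured and on what is new or still open speak of the compounds shown alone.

Of the compounds shown here, three have numbers so far. Compound 1 `C#CCSc1nc(Nc2ccccc2Cl)c(C#N)c(-c2ccccc2)n1` gives 24200 nM in a functional assay on MCF7 cells (Homo sapiens) for inhibition, read by MTT assay, with a stated time of 72 h; a higher number here means a weaker inhibitor, a lower number a stronger inhibitor. Compound 2 `COc1ccc(Nc2nc(SCc3cn(Cc4ccccc4Cl)nn3)nc(-c3ccccc3)c2C#N)cc1` gives 8050 nM in this assay, and compound 3 `N#Cc1c(Nc2cccc(C(F)(F)F)c2)nc(SCc2cn(Cc3ccccc3Cl)nn2)nc1-c1ccccc1` gives 12600 nM. Among these three, compound 3 holds the second highest number; its nearest neighbour is compound 2 and its furthest is compound 1, and both gaps lie within the scatter. Going by the values given here, the one step that can be counted here, a 1.6-fold higher number from compound 2 to compound 3 (0.19 log units; within the scatter), also lies within the scatter.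

Compound 4 `N#Cc1c(Nc2ccccc2Cl)nc(SCc2cn(Cc3ccccc3Cl)nn2)nc1-c1ccccc1` has not been measured. It differs from compound 3 in one place: 2-chlorophenyl in place of 3-(trifluoromethyl)phenyl on a nitrogen on an aromatic ring. Among the compounds with values here, the only measured step that bears on this kind of change is the aryl exchange on the same nitrogen, a 1.6-fold higher number from compound 2 to compound 3 (0.19 log units; within the scatter), which did not move the number beyond the scatter. Within the data shown here, compound 1 carries the same 2-chlorophenyl group as compound 4 but a different thioether, so its value shows only that this group is compatible with a number of this order, without giving a step of its own.

The expectation for this assay is therefore no change beyond the scatter, a 1.2-fold higher number from compound 3 to compound 4 (0.08 log units; within the scatter). Compound 4 is estimated at 15000 nM, with a range from 6000 nM to 40000 nM.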

Compound 4, half-maximal inhibitory concentration: 1950 nM
The estimate for compound 4 lay 7.7-fold (0.89 log units) above the measured number, outside the stated range (below it).
By their numbers in this assay, from the lowest: compound 4; then compounds 2, 3 and 1 (each within the scatter of the next, the first and the last beyond it).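

In this assay, going by these compounds alone, the aryl group on the nitrogen on an aromatic ring now proves able to move the number beyond the scatter: 2-chlorophenyl in place of 3-(trifluoromethyl)phenyl gives a 6.5-fold lower number from compound 3 to compound 4 (0.81 log units; beyond the scatter) and 2-chlorophenyl in place of 4-methoxyphenyl gives a 4.1-fold lower number from compound 2 to compound 4 (0.62 log units; beyond the scatter), whereas the only earlier step at this place, a 1.6-fold higher number from compound 2 to compound 3 (0.19 log units; within the scatter), did not. With the rest of the structure held constant across compound 2, compound 3 and compound 4, the 2-chlorophenyl group stands apart from the other two aryl groups, which stay within the scatter of each other. Nothing available gives a reason for these steps.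

The compounds shown leave open whether the chlorine itself carries the gain, a question that an unsubstituted phenyl, or a methyl or bromine in place of the chlorine, on the same nitrogen would address. Also open, from the compounds shown here alone, is whether the same aryl exchange would have a comparable effect with the thioether of compound 1 in place of the triazole-bearing chain.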